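Substituent change on the aromatic nitrogen of compound 2

The source may report more compounds than this note shows. Statements on the series, on what has been measured and on what is new or still open speak of the compounds shown alone.

Measured so far in a functional assay for antagonist activity at transient receptor potential cation channel subfamily V member 1 (Homo sapiens), read by FLIPR; a lower number here means a stronger inhibitor, a higher number a weaker inhibitor:
compound 1 `Cc1cccnc1-c1ccc(C(=O)Nc2ccc(C(C)(C)C)cc2)cc1`: 11 nM
compound 2 `CC(C)(C)c1ccc(NC(=O)c2ccc(-c3ncccc3NC3CCCC3)cc2)cc1`: 190 nM

For the measured compounds named here, compound 2 holds the higher of the two numbers; its only neighbour is compound 1, and the step of a 17-fold higher number from compound 1 to compound 2 (1.24 log units; beyond the scatter) was large and beyond the scatter. Compound 3 `CC(C)(C)c1ccc(NC(=O)c2ccc(-c3ncccc3NS(C)(=O)=O)cc2)cc1` differs from compound 2 by methylsulfonyl in place of cyclopentyl on a nitrogen on an aromatic ring. Going by the values given here, the single measured step bears on it only indirectly: it shows that substitution at this position of the core of compound 1 moved the number strongly, but no measured pair exchanges one group on the nitrogen for another, and nothing here covers a sulfonyl group. The change from compound 2 to compound 3 is therefore expected to give a step of a 2.1-fold higher number from compound 2 to compound 3 (0.32 log units; beyond the scatter), with the direction uncertain and a weakening thought somewhat more likely. Compound 3 is estimated at 400 nM in this assay, within 90 nM to 2000 nM.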

Compound 3, half-maximal inhibitory concentration: 152 nM
The estimate for compound 3 lay 2.6-fold (0.42 log units) above the measured number; low and high end bracket the measured number.
By their numbers in this assay, from the lowest: compound 1; then compounds 3 and 2 (each within the scatter of the next).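

In this assay the exchange on the nitrogen gives a 1.3-fold lower number from compound 2 to compound 3 (0.10 log units; within the scatter) and so does not separate methylsulfonyl from cyclopentyl, although the two groups differ in ring content and in hydrogen-bond acceptor count. Methanesulfonamido in place of methyl gives a 14-fold higher number from compound 1 to compound 3 (1.14 log units; beyond the scatter) while cyclopentylamino in place of methyl gave a 17-fold higher number from compound 1 to compound 2 (1.24 log units; beyond the scatter) and so the large step from compound 1 is now seen with two different groups on the nitrogen. No measurement at hand bears on why these two groups read alike.

As far as these compounds go, whether the large step follows from the nitrogen itself or from what it carries remains open, and the plain amino group, an acetyl group or a longer alkyl chain on that nitrogen would bear on this. Also open, from the compounds shown here alone, is how a chlorine or a methoxy group in place of methyl on the aromatic carbon would read.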